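The source may report more compounds than this note shows. Statements on the series, on what has been measured and on what is new or still open speak of the compounds shown alone.

Series notes. Within the data shown here, in an assay on HEK293 cells for agonist activity at transient receptor potential cation channel subfamily M member 8 (Homo sapiens), read by fluorescence and calcium flux, with a stated time of 15 min (on this read-out higher numbers stand for an effect only at larger amounts of compound and lower numbers for an effect already at smaller amounts), compound 3 `Cc1ccc(OCC(=O)N(Cc2cccs2)c2ncco2)cc1` gives 0.3 nM, the second highest of the three numbers so far; compound 2 `Cc1ccc(OCC(=O)N(Cc2cccs2)c2ccn[nH]2)cc1` gives 0.2 nM and compound 1 `Cc1ccc(OCC(=O)N(Cc2cccs2)c2cnn(C)c2)cc1` gives 63000 nM. The step from compound 3 to compound 4 `Cc1ccc(OCC(=O)N(Cc2cccs2)c2nccn2C)cc1` is 1-methyl-1H-imidazol-2-yl in place of 1,3-oxazol-2-yl on an amide-type nitrogen. Among the measured compounds shown here, the one direct exchange of rings on this nitrogen at the potent end, a 1.5-fold higher number from compound 2 to compound 3 (0.18 log units; within the scatter), was flat, whereas a 320000-fold lower number from compound 1 to compound 2 (5.50 log units; beyond the scatter) and a 210000-fold lower number from compound 1 to compound 3 (5.32 log units; beyond the scatter) show how far a ring change at this position can reach. The 1-methyl-1H-imidazol-2-yl ring of compound 4 shares a methyl with the 1-methyl-1H-pyrazol-4-yl ring of compound 1, so for compound 4 an upward step is expected, a 33-fold higher number from compound 3 to compound 4 (1.52 log units; beyond the scatter), with wide uncertainty. Compound 4 is estimated at 10 nM, range 0.3 nM to 1000 nM.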

Compound 4, half-maximal effective concentration: 1790 nM
Estimate against measurement, compound 4: 180-fold (2.25 log units) below; measured number above the stated range.
By their numbers in this assay, from the lowest: compounds 2 and 3 (each within the scatter of the next); then compound 4; then compound 1.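

In this assay, the exchange at the amide-type nitrogen is far from flat, even though the leaving and entering rings carry the same hydrogen-bond donor and acceptor counts (a 6000-fold higher number from compound 3 to compound 4 (3.78 log units; beyond the scatter)). The gap to the other potent ring is just as large (a 9000-fold higher number from compound 2 to compound 4 (3.95 log units; beyond the scatter)), yet the 1-methyl-1H-imidazol-2-yl ring stays clear of the 1-methyl-1H-pyrazol-4-yl ring (a 35-fold lower number from compound 1 to compound 4 (1.55 log units; beyond the scatter)), so these four compounds fall on three separate levels rather than two. Nothing available explains these steps.

Whether the rise follows the methyl or the ring itself stays open: the compounds shown include no 1H-imidazol-2-yl ring without the methyl and none with an ethyl in its place.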